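This account rests on a few compounds, and the source may have more. Where it says the series, first, only, none or still open, it means among the compounds named here.

Among the measured compounds shown here, compound 1 `COc1ccc(/C=C/C(=O)c2cc(-c3ccc(OC)c(OC)c3)n3nc(-c4ccccc4)cc3n2)cc1` is the weakest-looking of the three measured members, though not by much. In a functional assay on A549 cells (Homo sapiens) for antiproliferative activity, read by MTT assay, with a stated time of 24 h (a lower number here means a stronger inhibitor, a higher number a weaker inhibitor), compound 1 gives 19300 nM. Compound 2 `COc1cc(-c2cc(C(=O)/C=C/c3ccccc3)nc3cc(-c4ccccc4)nn23)cc(OC)c1OC` gives 18000 nM in this assay, a number that sits within the scatter of compound 1. Compound 3 `COc1ccc(-c2cc(/C=C/C(=O)c3ccc(OC)c(OC)c3)nc3cc(-c4ccccc4)nn23)cc1`, which carries its enone the other way round, with the carbonyl on the outer ring rather than on the core, gives 7400 nM in this assay, and that difference from compound 1 lies beyond the scatter.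

Compound 4 `COc1ccc(-c2cc(/C=C/C(=O)c3ccc(C)c(C)c3)nc3cc(-c4ccccc4)nn23)cc1OC` has not yet been measured. It differs from compound 1 in one place: 2-((3,4-dimethylphenyl)carbonyl)ethenyl in place of (2-(4-methoxyphenyl)ethenyl)carbonyl on an aromatic carbon. The enone of compound 4 is thus oriented like that of compound 3, with the carbonyl sitting on the outer ring, while the 3,4-dimethoxyphenyl group of compound 1 is kept.

For the measured compounds named here, no pair of measured compounds differs in this single place, so no measured step can be read off directly. Given that compound 3, with the same enone orientation, gives 7400 nM, the step from compound 1 to compound 4 is expected to be a modest one toward a lower number, a 2.0-fold lower number from compound 1 to compound 4 (0.31 log units; beyond the scatter). Compound 4 is estimated at 9500 nM, with a range from 4000 nM to 22000 nM.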

Compound 4, half-maximal inhibitory concentration: 9300 nM
Estimate against measurement, compound 4: 1.0-fold (0.01 log units) above; measured number inside the range.
By their numbers in this assay, from the lowest: compounds 3, 4, 2 and 1 (each within the scatter of the next, the first and the last beyond it).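

Among the compounds shown here, this is the first measured step at this aromatic carbon of the core, and it shows that the position responds to a change in the group it carries: in this assay, the result is a 2.1-fold lower number from compound 1 to compound 4 (0.32 log units; beyond the scatter). The step comes with the same number of heavy atoms in the leaving and entering groups and with one hydrogen-bond acceptor fewer, so a change of this kind need not enlarge the group to move the number beyond the scatter. Nothing measured here accounts for the step.

The single step joins two changes, the turned enone and the 3,4-dimethylphenyl ring in place of the 4-methoxyphenyl ring, and the compounds shown do not separate what each contributes. Also open, going by these compounds, is how this position would read with an unsubstituted phenyl ring or a chloro or amine substituent on the outer ring, or with a saturated two-carbon chain in place of the ethenyl link.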